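A few compounds are considered here, and "the series" means these few. Any claim that something is new, unique, unknown or untested is made for them only; others in the source may bear on it.

Three compounds share one core, and two of them show the same change applied to it. Compound 1, `Clc1ccc(Cn2cc(COc3ccccc3)nn2)cc1`, gives 26.1 ug/mL in a physicochemical assay, read by spectrophotometry, with a stated time of 30 min; a lower number here means a stronger inhibitor, a higher number a weaker inhibitor. Compound 2, `Clc1cccc(Cn2cc(COc3ccccc3)nn2)c1`, gives 27.3 ug/mL in this assay. Between them stands (3-chlorophenyl in place of 4-chlorophenyl on a saturated chain carbon bound to an aromatic nitrogen), and that step is a 1.0-fold higher number from compound 1 to compound 2 (0.02 log units; within the scatter). Compound 3, `Clc1ccc(Cn2cc(COc3ccc(Cl)cc3)nn2)cc1`, gives 26.1 ug/mL in this assay; it differs from compound 1 by chloro in place of hydrogen on an aromatic carbon, a step of no change at the digits printed from compound 1 to compound 3 (within the scatter). So far, none of the three numbers is separated from the others by more than the usual scatter.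

Compound 4, `Clc1ccc(OCc2cn(Cc3cccc(Cl)c3)nn2)cc1`, has not yet been measured. Among the measured compounds shown here, it differs from compound 3 by 3-chlorophenyl in place of 4-chlorophenyl on a saturated chain carbon bound to an aromatic nitrogen, which is the same change, at the same place, as the one that carried compound 1 to compound 2. Because that earlier step was a 1.0-fold higher number from compound 1 to compound 2 (0.02 log units; within the scatter), the same kind of outcome is expected here, and the step from compound 3 to compound 4 in this assay is estimated at a 1.0-fold higher number from compound 3 to compound 4 (0.01 log units; within the scatter). Compound 4 is therefore expected to give about 27 ug/mL in this assay, most likely between 18 ug/mL and 40 ug/mL.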

Compound 4, half-maximal inhibitory concentration: 23.3 ug/mL
The estimate for compound 4 lay 1.2-fold (0.06 log units) above the measured number; the range from low to high includes it.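

In this assay, the swap of 4-chlorophenyl for 3-chlorophenyl on the core of compound 3 gives a 1.1-fold lower number from compound 3 to compound 4 (0.05 log units; within the scatter) and on the core of compound 1 gives a 1.0-fold higher number from compound 1 to compound 2 (0.02 log units; within the scatter), so on both cores this swap stays within the usual scatter of repeated measurements. The other new step, chloro in place of hydrogen on an aromatic carbon, gives a 1.2-fold lower number from compound 2 to compound 4 (0.07 log units; within the scatter) and also stays within the scatter. This shows that the swap carried from one core to the other without a detectable effect, but it does not show a real shift in either direction, and two cores cannot establish a rule for others; no measurement shown here explains the result.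

The compounds shown leave open whether any change to these rings can move the number beyond the scatter. An amine or a carboxylic acid in place of the chloro group, or a longer chain in place of the saturated chain carbon, would be one way to test this.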